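This account rests on a few compounds, and the source may have more. Where it says the series, first, only, none or still open, it means among the compounds named here.

Measured so far:
- Compound 1 `Clc1ccc(C(c2c[nH]cc2-c2cccc3ccccc23)n2ccnc2)c(Cl)c1`: 12300 nM
- Compound 2 `c1ccc(C(c2ccn(-c3ccccc3)c2)n2ccnc2)cc1`: 80800 nM
- Compound 3 `Fc1ccc(-n2ccc(C(c3ccccc3)n3ccnc3)c2)cc1`: 104000 nM

In an ADME assay on L6 cells (Rattus norvegicus) for cytotoxicity, read by fluorescence and resazurin assay, with a stated time of 72 h (a lower number here means that less compound is tolerated, a higher number that more compound is tolerated), compound 3 gives 104000 nM. That is level, within the usual scatter, with compound 2 at 80800 nM, while compound 1 shows a clearly lower number at 12300 nM.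

The next compound, compound 4 `Fc1ccc(C(c2ccn(-c3ccc(F)cc3)c2)n2ccnc2)cc1`, has not yet been measured. It differs from compound 3 in one place: fluoro in place of hydrogen on an aromatic carbon. In words, this is fluoro in place of hydrogen on an aromatic carbon, turning a phenyl into a 4-fluorophenyl.

Within the data shown here, only one measured step is of the same kind, though it sits on a different ring: a 1.3-fold higher number from compound 2 to compound 3 (0.11 log units; within the scatter). A single step is thin evidence, but it gives no reason to expect a change beyond the scatter in this assay.

The expected step is a 1.2-fold lower number from compound 3 to compound 4 (0.06 log units; within the scatter), which would stay within the scatter.

For compound 4 the estimated value is 90000 nM, with an expected range from 42000 nM to 180000 nM.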

Compound 4, half-maximal cytotoxic concentration: 87100 nM
Compound 4: the middle estimate sits 1.0-fold (0.01 log units) above what was measured; the range from low to high includes it.
By their numbers in this assay, from the lowest: compound 1; then compounds 2, 4 and 3 (each within the scatter of the next).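

In this assay the change from phenyl to 4-fluorophenyl on this second ring (a 1.2-fold lower number from compound 3 to compound 4 (0.08 log units; within the scatter)) stays within the scatter, as did the same swap on the other phenyl ring (a 1.3-fold higher number from compound 2 to compound 3 (0.11 log units; within the scatter)). Compound 4 therefore carries a fluoro on both rings, and neither single change moves the tolerated concentration beyond the usual scatter. What one step could only hint at now holds at a second place, though only for this small set of compounds.

Fluoro adds just one heavy atom, so it remains open whether a different group at this place, such as an amine, a carboxylic acid or a longer chain, would move the number. Nothing available here offers an explanation for why these two steps stay so small.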